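This account rests on a few compounds, and the source may have more. Where it says the series, first, only, none or still open, it means among the compounds named here.

Values in a functional assay on HeLa cells (Homo sapiens) for inhibition, with a stated time of 72 h; a higher number here means that more compound is needed for the effect, a lower number that less compound is needed:
- Compound 1 `COc1cc(CNCc2ccncc2)ccc1OCc1ccccc1F`: 5100 nM
- Compound 2 `COc1cc(OCc2cnc(Cl)c(Cl)c2)ccc1CNCc1ccncc1`: 400 nM
- Compound 3 `COc1cc(CNCc2ccncc2)ccc1OCc1ccc(C)cc1`: 5000 nM
- Compound 4 `COc1cc(CNCc2ccncc2)ccc1OCc1ccc(F)cc1`: not yet measured

Compound 3 sits at the high end of the three numbers, within the scatter of compound 1, while compound 2 lies clearly lower. Compound 4 keeps the core of compound 3 and changes one substituent, 4-methylphenyl to 4-fluorophenyl: fluoro in place of methyl on an aromatic carbon. This is fluoro in place of methyl on an aromatic carbon, para to a large group.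

Among the measured compounds shown here, one measured step bears on this change. It replaces 2-fluorophenyl with 4-methylphenyl on the same chain carbon: a 1.0-fold lower number from compound 1 to compound 3 (0.01 log units; within the scatter). For the measured compounds named here, compound 2 differs from compound 3 in more than one place, so it gives no clean comparison, and no measured compound carries the 4-fluorophenyl group. Going by the values given here, with only this one flat step as a guide, no shift beyond the scatter is expected in this assay, though the evidence is thin and the range is kept wide.

The estimated step is no change at the digits printed from compound 3 to compound 4 (within the scatter).

Compound 4 is expected at 5000 nM, with an estimated range of 2200 nM to 11000 nM.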

Compound 4, half-maximal effective concentration: 6400 nM
Compound 4: the middle estimate sits 1.3-fold (0.11 log units) below what was measured; low and high end bracket the measured number.
By their numbers in this assay, from the lowest: compound 2; then compounds 3, 1 and 4 (each within the scatter of the next).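

At the aromatic carbon para to a large group, fluoro in place of methyl gives a 1.3-fold higher number from compound 3 to compound 4 (0.11 log units; within the scatter) in this assay, so this read-out does not separate these two groups, each of 1 heavy atom, at this position. The earlier compounds shown here held no pair with the same substituent type at two places on this ring; now 4-fluorophenyl in place of 2-fluorophenyl gives a 1.3-fold higher number from compound 1 to compound 4 (0.10 log units; within the scatter), and the place of the fluoro makes no difference beyond the scatter for this pair. Compounds 1, 3 and 4 thus form a level set of three on this ring, a statement that holds for these compounds only. No data are at hand that would explain why these numbers stay level.

On these data alone, whether an amine, a carboxylic acid or a longer chain on the same aromatic carbon would also stay within the scatter remains open, since the groups compared here are small and uncharged. Compound 2, at 400 nM, differs from these compounds in more than one place, so the share of each of its differences in that number cannot be separated.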